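A few compounds are considered here, and "the series" means these few. Any claim that something is new, unique, unknown or untested is made for them only; others in the source may bear on it.

Of the compounds shown here, three on a shared core have been measured in a functional assay on MGC-803 cells (Homo sapiens) for inhibition, read by MTT assay, with a stated time of 48 h; a higher number here means a weaker inhibitor, a lower number a stronger inhibitor. Compound 1 `CCC(=O)N(Cc1ccc(OC)c(O)c1)c1cc(OC)c(OC)c(OC)c1` gives 50 nM. Compound 2 `COc1ccc(CN(C(=O)C[Se]C#N)c2cc(OC)c(OC)c(OC)c2)cc1O` gives 270 nM, and compound 3 `COc1ccc(CN(C(=O)CN=[N+]=[N-])c2cc(OC)c(OC)c(OC)c2)cc1O` gives 120 nM. Compound 3 therefore stands second highest of the three numbers, nearer to compound 2 than to compound 1. All three differ only at the saturated chain carbon bound to the carbonyl carbon, and the steps there were modest: a 5.4-fold higher number from compound 1 to compound 2 (0.73 log units; beyond the scatter), a 2.4-fold higher number from compound 1 to compound 3 (0.38 log units; beyond the scatter) and a 2.3-fold lower number from compound 2 to compound 3 (0.35 log units; beyond the scatter).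

Compound 4 `COCC(=O)N(Cc1ccc(OC)c(O)c1)c1cc(OC)c(OC)c(OC)c1` has not yet been measured. It differs from compound 3 by methoxy in place of azido on a saturated chain carbon bound to a carbonyl carbon. Going by the values given here, the steps that bear on this change are the two that replaced the methyl of compound 1 at the same place, a 2.4-fold higher number from compound 1 to compound 3 (0.38 log units; beyond the scatter) and a 5.4-fold higher number from compound 1 to compound 2 (0.73 log units; beyond the scatter), both toward a weaker inhibitor, while compound 1 itself holds the lowest number. Among the compounds with values here, a methoxy is a third replacement at that carbon; the data give no direct precedent for it. Because a 2.4-fold higher number from compound 1 to compound 3 (0.38 log units; beyond the scatter) was modest, compound 4 is expected to land between compound 1 and compound 3, with the estimated step being a 1.5-fold lower number from compound 3 to compound 4 (0.18 log units; within the scatter). Compound 4 is accordingly expected to give 80 nM in this assay, within a range from 35 nM to 200 nM.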

Compound 4, half-maximal inhibitory concentration: 79 nM
Beside the measured number, compound 4's estimate is 1.0-fold (0.01 log units) above it, within the range that was stated.
By their numbers in this assay, from the lowest: compounds 1, 4 and 3 (each within the scatter of the next, the first and the last beyond it); then compound 2.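

In this assay, going by these compounds alone, methoxy is the first replacement of the methyl of compound 1 at the saturated chain carbon bound to a carbonyl carbon to stay within the scatter (a 1.6-fold higher number from compound 1 to compound 4 (0.20 log units; within the scatter)), so this carbon does not lose activity with every change to the group it carries. The change from azido is also within the scatter (a 1.5-fold lower number from compound 3 to compound 4 (0.18 log units; within the scatter)), so compound 4 cannot be told apart from either compound 1 or compound 3, although those two are separated beyond the scatter. Only the selenium-bearing group of compound 2 remains apart from all the others, and the methoxy compound confirms this with a modest step (a 3.4-fold lower number from compound 2 to compound 4 (0.53 log units; beyond the scatter)), though no measurement shown explains why the numbers fall as they do.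

The compounds shown leave open whether an amine, a carboxylic acid, a hydroxyl or a longer chain such as ethoxy at this carbon would also stay level with compound 1. They also vary only this one place on the shared core, so they cannot tell whether the same replacements would behave alike with any other part of the molecule changed.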